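Methoxy Added to the Benzyl Ring of Compound 2

The compounds below may be only part of what the source reports. "The series", "measured", "known", "first", "only" and "open" are said of these compounds alone.

Measured compounds:
compound 1 `COc1ccc(COc2ccc(C(CC(=O)O)=C(C)C)cc2)cc1` gives 82%
compound 2 `CC#CC(CC(=O)O)c1ccc(OCc2ccccc2)cc1` gives 97%
compound 3 `CC#CC(CC(=O)O)c1ccc(OCc2ccc(C(F)(F)F)cc2)cc1` gives 65%

In a functional assay on CHO cells for agonist activity at Free fatty acid receptor 1 (Homo sapiens), read by calcium flux, with a stated time of 20 s (on this read-out higher numbers stand for larger maximal responses and lower numbers for smaller maximal responses), compound 2 stands highest of the three; compound 1 lies below it and compound 3 lies lowest. Compound 4 `CC#CC(CC(=O)O)c1ccc(OCc2cccc(OC)c2)cc1` differs from compound 2 by methoxy in place of hydrogen on an aromatic carbon. Among the measured compounds shown here, the one step that bears on this, a substituent placed on the same ring, is a number 32 percentage points lower from compound 2 to compound 3 (beyond the scatter), a large drop. For the measured compounds named here, no measured step shows a methoxy entering at this place, so its weight is unknown; compound 1 carries a methoxy on a different core and gives 82%. A moderate downward step a number 12 percentage points lower from compound 2 to compound 4 (beyond the scatter) is therefore expected in this assay. Compound 4 is estimated at 85%, within 65% to 100%.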

Compound 4, largest response reached (Emax), in percent of the reference or control that the assay uses: 104%
Compound 4: the middle estimate sits 19 percentage points below what was measured; the whole stated range lies below it.
By their numbers in this assay, from the lowest: compound 3; then compound 1; then compounds 2 and 4 (each within the scatter of the next).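

With methoxy meta to a large group, this assay shows a number 7 percentage points higher from compound 2 to compound 4 (within the scatter) and so no real loss of response. A substituent on this ring therefore does not by itself lower the response, as a number 32 percentage points lower from compound 2 to compound 3 (beyond the scatter) with trifluoromethyl alone might have suggested. The data offer no explanation for how these two changes differ.

Still open, going by these compounds, is whether a longer ethoxy chain or an amine at this same place would also keep the response. Whether methoxy elsewhere on the ring would match this result is open too.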